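The source may report more compounds than this note shows. Statements on the series, on what has been measured and on what is new or still open speak of the compounds shown alone.

Compound 1 `O=C(CCc1ccc(-c2ccccc2F)cc1)N1CCCC1`: 2800 nM
Compound 2 `CCCc1ccc(CCCCCCC(=O)N2CCCC2)cc1`: > 100000 nM

Going by the values given here, in an assay on HEK293 cells for inhibition of N-acylethanolamine-hydrolyzing acid amidase (Rattus norvegicus), read by LC-MS, with a stated time of 30 min (a higher number here means a weaker inhibitor, a lower number a stronger inhibitor), compound 1 gives 2800 nM, the only number reported. Compound 2 reaches only a limit, (the limit of > 100000 nM in this assay, at which 1 of the 2 values shown sits). The step under study goes from compound 1 to compound 3 `O=C(CCc1ccc(Oc2ccccc2)cc1)N1CCCC1`, where (phenoxy in place of 2-fluorophenyl on an aromatic carbon). Among the compounds with values here, no measured pair shows what such a change does, so the expected step in this assay is small, none beyond the usual scatter, in either direction. Compound 3 is therefore expected to give 3000 nM, within 800 nM to 12000 nM. The expected step is a 1.1-fold higher number from compound 1 to compound 3 (0.03 log units; within the scatter).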

Compound 3, half-maximal inhibitory concentration: > 100000 nM
Compound 3: no number, only a limit; the forecaster's own chance of this, stated with the estimate: 10%; at least 33-fold (1.52 log units) between middle value and limit.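

Phenoxy in place of 2-fluorophenyl gives an at least 35-fold higher number from compound 1 to compound 3 (1.55 log units; beyond the scatter), so this aromatic carbon, para to a group of 9 heavy atoms, does not accept the exchange freely, even though both groups hold 7 heavy atoms. In this assay compound 3 gives > 100000 nM, which is a limit and not a number, so the full size of the step cannot be read: the limit of > 100000 nM in this assay, at which 2 of the 3 values shown sit.

The compounds shown leave open whether the step follows from losing the fluorine or from gaining the oxygen. A plain phenyl group at this carbon is not among them, nor is a benzyloxy group or an amine.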